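The source may hold more compounds than are shown below. What is called first, only, known or untested is meant among the compounds shown, and "the series" means these compounds.

Working notes on the series built around compound 1 `Cc1ccc(C(=O)Nc2cccc(NC(=O)COc3ccc4c(=O)ccoc4c3)c2)cc1`. Within the data shown here, in an assay on isolated protein for inhibition of Rho-associated protein kinase 1 (Homo sapiens), read by scintillation counting, radiometric assay and 33P incorporation, with a stated time of 40 min, in the presence of a further agent that is not named here (on this read-out lower numbers stand for stronger inhibition and higher numbers for weaker inhibition), compound 1 gives 183 nM, and that is the only number so far in hand. Compound 2 `O=C(COc1ccc2c(=O)ccoc2c1)Nc1cccc(NS(=O)(=O)c2ccc(C(F)(F)F)cc2)c1` returns only a limit of the assay, > 10000 nM, not a number; this is the limit of > 10000 nM in this assay, at which 1 of the 2 values shown sits. Compound 3 `Nc1cccc(C(=O)Nc2cccc(NC(=O)COc3ccc4c(=O)ccoc4c3)c2)c1` remains to be measured. The change from compound 1 is 3-aminophenyl in place of 4-methylphenyl on a carbonyl carbon. Among the measured compounds shown here, no measured step of this kind is available, so the step is expected to be small, at most a little weaker than compound 1. The expected step from compound 1 to compound 3 is a 1.6-fold higher number from compound 1 to compound 3 (0.21 log units; within the scatter). Compound 3 is estimated at 300 nM, between 80 nM and 1500 nM.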

Compound 3, half-maximal inhibitory concentration: 670 nM
Estimate against measurement, compound 3: 2.2-fold (0.35 log units) below, within the range that was stated.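

In this assay, among these compounds, 3-aminophenyl in place of 4-methylphenyl on a carbonyl carbon gives a 3.7-fold higher number from compound 1 to compound 3 (0.56 log units; beyond the scatter), the first step that can be read at a single place. This position is therefore sensitive to this change, though compound 3 still gives a measured value rather than a limit of the assay. Nothing in hand bears on why the step occurs.

The change replaces the methyl group with an amine and alters the substitution on the ring together, so these two remain unseparated. An unsubstituted phenyl or a methoxyphenyl group at this place would speak to that.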